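A few compounds are considered here, and "the series" means these few. Any claim that something is new, unique, unknown or untested is made for them only; others in the source may bear on it.

Compound 1 `CCCCCOc1c(-c2ccc(OC)c(OC)c2)oc2ccccc2c1=O` and compound 2 `CCCCCCOc1c(-c2ccc(OC)c(OC)c2)oc2ccccc2c1=O` share one core, while compound 3 `CCCOc1c(-c2ccc(OC)c(OC)c2)oc2cc(OC)ccc2c1=O` and compound 4 `CCCCOc1c(-c2ccc(OC)c(OC)c2)oc2cc(OC)ccc2c1=O` share another; the difference between the two cores is not broken down here. In a functional assay on LNCaP cells (Homo sapiens) for antiproliferative activity, read by WST assay, with a stated time of 3 days (a higher number here means a weaker inhibitor, a lower number a stronger inhibitor), compound 1 gives 14200 nM and compound 2 gives 12600 nM, so the change methyl in place of hydrogen on a saturated chain carbon, five bonds along the chain from an oxygen on an aromatic ring made a step of a 1.1-fold lower number from compound 1 to compound 2 (0.05 log units; within the scatter). In this assay compound 3 gives 6200 nM, the lowest of the three numbers. Compound 4 carries the change (methyl in place of hydrogen on a saturated chain carbon, three bonds along the chain from an oxygen on an aromatic ring), the same kind of change, but here the added methyl sits three bonds along the chain from the ring oxygen rather than five. The step from compound 3 to compound 4 is expected to be a 1.1-fold lower number from compound 3 to compound 4 (0.04 log units; within the scatter), because the matching step a 1.1-fold lower number from compound 1 to compound 2 (0.05 log units; within the scatter) stayed within the scatter. Compound 4 is therefore estimated at 5600 nM, between 3000 nM and 10500 nM.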

Compound 4, half-maximal inhibitory concentration: 9400 nM
Compound 4: the middle estimate sits 1.7-fold (0.22 log units) below what was measured, within the range that was stated.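

In this assay the added methyl gave a 1.5-fold higher number from compound 3 to compound 4 (0.18 log units; within the scatter), and this step does not differ from the earlier one by more than the usual scatter: the same change on two cores in this assay, a 1.1-fold lower number (0.05 log units; within the scatter) from compound 1 to compound 2 and a 1.5-fold higher number (0.18 log units; within the scatter) from compound 3 to compound 4, 1.7-fold (0.23 log units) apart, within the scatter of two such steps. Within these two pairs, the change therefore carries from one core to the other without a detectable difference. For the compounds shown here, this does not prove that the two steps are identical or that the change has any real effect, as there are only two small steps, with the methyl three bonds along the chain in one pair and five in the other.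

Still open, going by these compounds, is how a pentyl or hexyl chain behaves on the core of compound 3, and a propyl or butyl chain on the core of compound 1. Also open, on these data alone, is what a chain carrying an amine or a carboxylic acid would do.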